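Benzoyl ring substitution and microsomal clearance in the series

A few compounds are considered here, and "the series" means these few. Any claim that something is new, unique, unknown or untested is made for them only; others in the source may bear on it.

Compound 3 `CC(C)NC(=O)[C@H]1CC[C@@H](n2/c(=N/C(=O)c3ccccc3)[nH]c3ccc(CN4CCC(C(C)(C)O)CC4)cc32)CC1` carries an unsubstituted benzoyl group on the shared core. Going by the values given here, in an in vitro ADME assay on microsomes from liver (Homo sapiens) for metabolic stability (a lower number here means slower removal, a higher number faster removal of the compound), compound 3 gives 40 mL.min-1.g-1, the lowest of the three numbers known, though the gap to compound 1 `CC(C)NC(=O)[C@H]1CC[C@@H](n2/c(=N/C(=O)c3ccc(F)c(F)c3)[nH]c3ccc(CN4CCC(C(C)(C)O)CC4)cc32)CC1` with 60 mL.min-1.g-1 lies within the scatter (a 1.5-fold lower number from compound 1 to compound 3 (0.18 log units; within the scatter)). Compound 2 `CC(C)NC(=O)[C@H]1CC[C@@H](n2/c(=N/C(=O)c3ccc(C#N)c(F)c3)[nH]c3ccc(CN4CCC(C(C)(C)O)CC4)cc32)CC1`, with 132 mL.min-1.g-1, sits clearly higher (a 3.3-fold lower number from compound 2 to compound 3 (0.52 log units; beyond the scatter)), and the step of a 2.2-fold higher number from compound 1 to compound 2 (0.34 log units; beyond the scatter) shows the cyano analogue removed faster than the difluoro one.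

Compound 4 `CC(C)NC(=O)[C@H]1CC[C@@H](n2/c(=N/C(=O)c3ccc(F)c(Cl)c3)[nH]c3ccc(CN4CCC(C(C)(C)O)CC4)cc32)CC1` differs from compound 3 as follows: 3-chloro-4-fluorophenyl in place of phenyl on a carbonyl carbon. The measured steps that bear on it are the return to phenyl from 3,4-difluorophenyl, a 1.5-fold lower number from compound 1 to compound 3 (0.18 log units; within the scatter), within the scatter, and from 4-cyano-3-fluorophenyl, a 3.3-fold lower number from compound 2 to compound 3 (0.52 log units; beyond the scatter), beyond it. Both substituted rings gave higher numbers than compound 3, so a modest rise is expected for compound 4, a 1.8-fold higher number from compound 3 to compound 4 (0.24 log units; within the scatter), though a result within the scatter would not surprise. Compound 4 is therefore estimated at 70 mL.min-1.g-1 in this assay, with a range from 35 mL.min-1.g-1 to 140 mL.min-1.g-1.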

Compound 4, intrinsic clearance in microsomes: 83 mL.min-1.g-1
Compound 4: middle estimate off by 1.2-fold (0.07 log units), on the low side; low and high end bracket the measured number.
By their numbers in this assay, from the lowest: compounds 3, 1, 4 and 2 (each within the scatter of the next, the first and the last beyond it).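

In this assay the change to 3-chloro-4-fluorophenyl gives a 2.1-fold higher number from compound 3 to compound 4 (0.32 log units; beyond the scatter) and so stands beyond the scatter against the unsubstituted benzoyl group, which the 3,4-difluorophenyl ring of compound 1 did not. The comparisons with the other two substituted rings give a 1.4-fold higher number from compound 1 to compound 4 (0.14 log units; within the scatter) and a 1.6-fold lower number from compound 2 to compound 4 (0.20 log units; within the scatter), so both steps lie within the scatter and compound 4 separates from neither neighbour. Nothing at hand accounts for these differences.

Still open, going by these compounds, is whether a ring carrying a single halogen, rather than two substituents, already departs from compound 3. The compounds shown also leave open how an amine, a carboxylic acid or a methoxy group on this ring would read in this assay.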